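The compounds below may be only part of what the source reports. "The series", "measured", "known", "first", "only" and "open" are said of these compounds alone.

In a functional assay, with a stated time of 6 min (a lower number here means a stronger inhibitor, a higher number a weaker inhibitor), compound 3 `S=c1oc(-c2ccc3c(c2)OCCO3)nn1CNc1ccccc1Cl` gives 7230 nM. That lies within the scatter of compound 1 `CCOc1ccccc1NCn1nc(-c2ccc3c(c2)OCCO3)oc1=S` at 5280 nM and of compound 2 `Fc1ccc(NCn2nc(-c3ccc4c(c3)OCCO4)oc2=S)cc1` at 6480 nM. Compound 4 `S=c1oc(-c2ccc3c(c2)OCCO3)nn1CNc1cccc(Cl)c1` differs from compound 3 by one change: 3-chlorophenyl in place of 2-chlorophenyl on an amine nitrogen, with 3-chlorophenyl in place of 2-chlorophenyl on an amine nitrogen. Among the measured compounds shown here, no measured pair shows this exact swap. The closest evidence comes from changes to the same group, namely a 1.1-fold higher number from compound 2 to compound 3 (0.05 log units; within the scatter) and a 1.4-fold higher number from compound 1 to compound 3 (0.14 log units; within the scatter), and both stay within the scatter. No shift beyond the scatter is therefore expected in this assay, and the expected step is a 1.1-fold lower number from compound 3 to compound 4 (0.05 log units; within the scatter). Compound 4 is estimated at 6500 nM, with an expected range of 3000 nM to 13000 nM.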

Compound 4, half-maximal inhibitory concentration: 6220 nM
Estimate against measurement, compound 4: 1.0-fold (0.02 log units) above, and the stated range covers the measured number.
By their numbers in this assay, from the lowest: compounds 1, 4, 2 and 3 (each within the scatter of the next).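

In this assay moving the chlorine, from 2-chlorophenyl to 3-chlorophenyl on the amine nitrogen, gives a 1.2-fold lower number from compound 3 to compound 4 (0.07 log units; within the scatter) and so leaves the number unchanged within the scatter. Compound 4 also stays within the scatter of the other two compounds, with a 1.0-fold lower number from compound 2 to compound 4 (0.02 log units; within the scatter) and a 1.2-fold higher number from compound 1 to compound 4 (0.07 log units; within the scatter), so all four substituted phenyl groups on this nitrogen read alike. Nothing available explains this flat result. As far as these compounds go, whether a carboxylic acid or a longer chain in place of the phenyl ring would shift the number beyond the scatter stays open.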